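The source may hold more compounds than are shown below. What is called first, only, known or untested is meant among the compounds shown, and "the series" means these compounds.

In an assay on Midbrain with Type-2 angiotensin II receptor (Rattus norvegicus) as the target (a lower number here means a stronger inhibitor, a higher number a weaker inhibitor), compound 3 `CCCCc1cc(Cn2c(CC)nc3c(C)cc(C)nc32)ccc1OC(C(=O)O)c1ccccc1` gives 140 nM, the lowest of the three numbers recorded. Compound 2 `CCc1nc2c(C)cc(C)nc2n1Cc1ccc(OC(C(=O)O)c2ccccc2)c(C)c1` gives 940 nM in this assay, and compound 1 `CCc1nc2c(C)cc(C)nc2n1Cc1ccc(OC(C(=O)O)c2ccccc2Cl)cc1` gives 15000 nM, so compound 3 stands a clear way in front of both.

Compound 4 `CCc1nc2c(C)cc(C)nc2n1Cc1ccc(OC(C(=O)O)c2ccccc2)c(C(=O)c2ccccc2)c1` has not been measured. It differs from compound 3 by benzoyl in place of butyl on an aromatic carbon. For the measured compounds named here, the one measured step that touches this position is a 6.7-fold lower number from compound 2 to compound 3 (0.83 log units; beyond the scatter), which showed that adding carbon to the chain on that aromatic carbon brought a modest gain. Going by the values given here, no measured pair shows what happens when the chain is replaced by a group carrying a ring and a carbonyl, so the new change has no direct precedent among the three compounds. Given only this, compound 4 is expected to sit near compound 3 or somewhat behind it, with a wide margin, meaning a 2.1-fold higher number from compound 3 to compound 4 (0.33 log units; beyond the scatter). The estimate for compound 4 in this assay is 300 nM, with a range from 60 nM to 1500 nM.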

Compound 4, half-maximal inhibitory concentration: 60 nM
The estimate for compound 4 lay 5.0-fold (0.70 log units) above the measured number; measured number inside the range.
By their numbers in this assay, from the lowest: compound 4; then compound 3; then compound 2; then compound 1.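

In this assay the exchange of butyl for benzoyl gives a 2.3-fold lower number from compound 3 to compound 4 (0.37 log units; beyond the scatter) and so shows that the gain at this aromatic carbon, ortho to a carboxy(phenyl)methoxy group, is not confined to a saturated chain. A group carrying a six-membered aromatic ring and a carbonyl goes further here than butyl did. Set against methyl, the same group gives a 16-fold lower number from compound 2 to compound 4 (1.19 log units; beyond the scatter) and this is a large step, whereas the earlier compounds had shown only a modest one at this position.

The compounds shown do not separate the share of the carbonyl from that of the ring, which a benzyl group or an acetyl group at this carbon would begin to do. Nothing further is available that bears on why benzoyl gives the lower number.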